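Hexafluoro-carbinol naphthylamides: aryl to oxazolyl amide

The source may report more compounds than this note shows. Statements on the series, on what has been measured and on what is new or still open speak of the compounds shown alone.

Measured compounds:
compound 1, `CC(C)CCC(=O)Nc1c(C(O)(C(F)(F)F)C(F)(F)F)ccc2ccccc12` — 49 nM
compound 2, `O=C(Nc1ccc(Cl)cc1)Nc1c(C(O)(C(F)(F)F)C(F)(F)F)ccc2ccccc12` — 276 nM
compound 3, `Cc1cccc(C(=O)Nc2c(C(O)(C(F)(F)F)C(F)(F)F)ccc3ccccc23)c1` — 23 nM

All three share one core and differ only in the group on the carbonyl carbon. In an assay on LtK cells with ATP-sensitive inward rectifier potassium channel 11 (Homo sapiens) as the target (a higher number here means that more compound is needed for the effect, a lower number that less compound is needed), compound 3 gives the lowest number of the three; compound 1 is nearest and compound 2 furthest, both steps beyond the scatter, so compound 3 is the most potent of the measured set.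

Compound 4, `O=C(Nc1c(C(O)(C(F)(F)F)C(F)(F)F)ccc2ccccc12)c1cnco1`, carries 1,3-oxazol-5-yl in place of 3-methylphenyl on a carbonyl carbon. Among the compounds with values here, no measured step exchanges one aromatic ring for another, so the bearing steps are indirect: a 2.1-fold lower number from compound 1 to compound 3 (0.33 log units; beyond the scatter) and a 12-fold lower number from compound 2 to compound 3 (1.08 log units; beyond the scatter) show the amide with the six-membered carbon ring ahead of both the isopentyl amide and the urea. Within the data shown here, a five-membered ring with two hetero atoms in the same place has no precedent here; the expectation is that compound 4 gives a modestly higher number, a 3.0-fold higher number from compound 3 to compound 4 (0.48 log units; beyond the scatter), in this assay. Compound 4 is estimated at 70 nM, within 25 nM to 200 nM.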

Compound 4, half-maximal effective concentration: 24 nM
Compound 4: the middle estimate sits 2.9-fold (0.46 log units) above what was measured; measured number below the stated range.
By their numbers in this assay, from the lowest: compounds 3 and 4 (each within the scatter of the next); then compound 1; then compound 2.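

In this assay, the position on the carbonyl carbon accepts 1,3-oxazol-5-yl as well as 3-methylphenyl, with a 1.0-fold higher number from compound 3 to compound 4 (0.02 log units; within the scatter): a five-membered aromatic ring with 2 hetero atoms and 2 hydrogen-bond acceptors reads the same as a six-membered aromatic ring of carbon only. The standing of the aromatic amides over the other two groups also holds for the new ring, with a 12-fold lower number from compound 2 to compound 4 (1.06 log units; beyond the scatter) and a 2.0-fold lower number from compound 1 to compound 4 (0.31 log units; beyond the scatter), so among these compounds a six-membered carbon ring is not required here. No supporting data bear on why the two rings read alike.

Open, from the compounds shown here alone, is whether either ring hetero atom matters, which a furan or thiazole ring at this position would test. Also open, going by these compounds, is whether a plain phenyl or pyridine ring would read the same as these two rings.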